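The source may report more compounds than this note shows. Statements on the series, on what has been measured and on what is new or still open speak of the compounds shown alone.

Series notes, cytotoxicity. Going by the values given here, the three compounds measured so far share one core and differ only in the aryl group on the sulfonyl sulfur. Compound 1 `CC(C)(C)c1ccc(S(=O)(=O)N2CCC[C@@H]2C(=O)N2CCN(c3ccnc4cc(Cl)ccc34)CC2)cc1` gives 53100 nM in an ADME assay on HEK293 cells (Homo sapiens) for cytotoxicity, read by MTT assay, with a stated time of 48 h; on this read-out higher numbers stand for weaker inhibition and lower numbers for stronger inhibition; compound 2 `O=C([C@H]1CCCN1S(=O)(=O)c1ccccc1[N+](=O)[O-])N1CCN(c2ccnc3cc(Cl)ccc23)CC1` gives 57700 nM; compound 3 `Cc1ccc(S(=O)(=O)N2CCC[C@@H]2C(=O)N2CCN(c3ccnc4cc(Cl)ccc34)CC2)cc1` gives 81200 nM. Compound 2 thus sits second highest of the three numbers, closest to compound 1 and furthest from compound 3, and every step among them lies within the scatter: a 1.1-fold higher number from compound 1 to compound 2 (0.04 log units; within the scatter), a 1.5-fold higher number from compound 1 to compound 3 (0.18 log units; within the scatter), a 1.4-fold higher number from compound 2 to compound 3 (0.15 log units; within the scatter).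

Compound 4 `O=C([C@H]1CCCN1S(=O)(=O)c1ccccc1)N1CCN(c2ccnc3cc(Cl)ccc23)CC1` is not yet measured. From compound 2 it changes as follows: hydrogen in place of nitro on an aromatic carbon. Among the compounds with values here, the steps that bear on it are the two that replace the aryl group on the sulfonyl sulfur, a 1.1-fold higher number from compound 1 to compound 2 (0.04 log units; within the scatter) and a 1.4-fold higher number from compound 2 to compound 3 (0.15 log units; within the scatter), neither of which moved the read-out beyond the scatter. Removing the nitro group is therefore expected to give no step beyond the scatter, the estimated step being a 1.0-fold higher number from compound 2 to compound 4 (0.02 log units; within the scatter). The estimate for compound 4 is 60000 nM, with a range from 30000 nM to 120000 nM.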

Compound 4, half-maximal inhibitory concentration: 64100 nM
The estimate for compound 4 lay 1.1-fold (0.03 log units) below the measured number, within the range that was stated.
By their numbers in this assay, from the lowest: compounds 1, 2, 4 and 3 (each within the scatter of the next).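

The phenyl of compound 4 gives the series a reference with no substituent on this ring, tested in this assay and compared directly with the substituted aryl groups. Hydrogen in place of nitro, ortho to a large group, stays within the scatter (a 1.1-fold higher number from compound 2 to compound 4 (0.05 log units; within the scatter)), as do hydrogen in place of methyl (a 1.3-fold lower number from compound 3 to compound 4 (0.10 log units; within the scatter)) and hydrogen in place of tert-butyl (a 1.2-fold higher number from compound 1 to compound 4 (0.08 log units; within the scatter)), so among these four compounds neither the presence of a substituent nor its kind separates the numbers. No measurement at hand explains this flat result.

Still open, going by these compounds, is whether an amine or a carboxylic acid on this ring would give a step beyond the scatter. The compounds shown also leave open whether the numbers stay this close when the sulfonyl-bearing aryl group is replaced by a longer alkyl chain.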